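The compounds below may be only part of what the source reports. "The series", "measured", "known", "first", "only" and "open" are said of these compounds alone.

Three ureas built on a shared core were examined in an ADME assay on BJ cells (Homo sapiens) for cytotoxicity, with a stated time of 72 h; on this read-out lower numbers stand for an effect already at smaller amounts and higher numbers for an effect only at larger amounts of compound. Compound 1 `Cc1cc(NC(=O)Nc2ccccc2N)c2ccccc2n1` returns only a limit of the assay, and in this assay compound 1 gives > 25000 nM. Compound 2 `Cc1cc(NC(=O)Nc2cccc([N+](=O)[O-])c2)c2ccccc2n1` also returns a limit; in this assay compound 2 gives > 25000 nM. Compound 3 `Cc1cc(NC(=O)Nc2cccc(C(F)(F)F)c2)c2ccccc2n1` stops at a limit as well, and in this assay compound 3 gives > 25000 nM. Because both ends are limits, the step from compound 2 to compound 3 is a step that the two limits leave unreadable from compound 2 to compound 3 and its size cannot be read. Within the data shown here, the record the limit of > 25000 nM in this assay, at which 3 of the 3 values shown sit, shows that every value so far sits at that same point, so compound 3 stands level with compound 1 and compound 2, with no ordering among the three.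

Compound 4 `Cc1cc(NC(=O)Nc2cccc(Cl)c2)c2ccccc2n1` differs from compound 3 in a single place: chloro in place of trifluoromethyl on an aromatic carbon. Among the measured compounds shown here, the one measured step that touches compound 3 is a step that the two limits leave unreadable from compound 2 to compound 3, which two limits leave unreadable, so no measured step gives a readable size for this change. Against that background, compound 4 is expected to follow the other three to the limit, and the step from compound 3 to compound 4 is estimated at a step that the limit leaves unreadable from compound 3 to compound 4, with no shift beyond the scatter expected. In this assay compound 4 is therefore estimated at 40000 nM, within a range from 20000 nM to 100000 nM.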

Compound 4, half-maximal effective concentration: > 25000 nM
Compound 4 gave a limit, no number (the forecaster's own chance of this, stated with the estimate: 85%); the middle value is on the limit's open side.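

Compound 4 also returns only a limit, so its steps from compound 1, compound 2 and compound 3 cannot be read, and no order among the four can be stated: the limit of > 25000 nM in this assay, at which 4 of the 4 values shown sit. The compounds shown leave open whether any urea on the shared core would give a readable number in this assay.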